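Working notes on stability within a small O-substituted series

This account rests on a few compounds, and the source may have more. Where it says the series, first, only, none or still open, it means among the compounds named here.

The three measured compounds share a core whose structure stands beside each entry: compound 1 `CC(C)N/[N+]([O-])=N/O`, compound 2 `CC(C)N/[N+]([O-])=N/OCCS(=O)(=O)NOCc1ccccc1` and compound 3 `CC(=O)OCO/N=[N+](\[O-])NC(C)C`. In a physicochemical assay for metabolic stability, read by spectrophotometry, in phosphate buffer, at pH 7.4 (on this read-out higher numbers stand for a longer-lived compound and lower numbers for a shorter-lived compound), compound 1 gives 0.0383 h, compound 3 gives 0.683 h and compound 2 gives 6.6 h. On these numbers compound 2 stands highest; its nearest neighbour is compound 3, whose number is lower by a gap beyond the scatter, and the widest gap is to compound 1, which lies far below it. For the measured compounds named here, no pair among the measured compounds differs in only one place, so no single step can be read off directly.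

Compound 4 `CONS(=O)(=O)CCO/N=[N+](\[O-])NC(C)C` is the next compound to go into this assay. It differs from compound 2 as follows: hydrogen in place of phenyl on a saturated chain carbon bound to an oxygen. The portion of compound 2 that carries the sulfonyl chain stays in place, so the change is confined to the far end of that chain. Going by the values given here, with no measured step of this kind to lean on, the step from compound 2 to compound 4 is expected to be small, most likely within the scatter or a modest drop: a 1.7-fold lower number from compound 2 to compound 4 (0.22 log units; within the scatter). Compound 4 is estimated at 4 h, within a range of 1.5 h to 12 h.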

Compound 4, half-life: 8.9 h
Compound 4: middle estimate off by 2.2-fold (0.35 log units), on the low side, within the range that was stated.
By their numbers in this assay, from the lowest: compound 1; then compound 3; then compounds 2 and 4 (each within the scatter of the next).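

In this assay, for the compounds shown here, the exchange of phenyl for hydrogen on a saturated chain carbon bound to an oxygen gives a 1.3-fold higher number from compound 2 to compound 4 (0.13 log units; within the scatter) and supplies the first measured step that differs in one place. At the far end of the sulfonyl chain, the half-life therefore holds within the scatter with or without the six-membered aromatic ring, so on this pair the ring is not needed to keep the number where it stands; the same difference, cut one bond further out, reads benzyl to methyl. Nothing measured on these compounds accounts for this outcome.

Going by these compounds, whether the far end of the chain stays as undemanding with an amine, a carboxylic acid or a longer chain in place of the methyl remains open, as one step on one pair sets no rule for other groups at this position. What the sulfonyl chain itself contributes also remains open, as no pair among the compounds shown differs in that part alone.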